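Sulfonyl substituent changes on a shared core

A few compounds are considered here, and "the series" means these few. Any claim that something is new, unique, unknown or untested is made for them only; others in the source may bear on it.

Compound 1 `COS(=O)(=O)c1ccc(F)c2ncc(I)cc12`: in an assay for inhibition of methylcytosine dioxygenase TET2 (Homo sapiens), read by mass spectrometry, with stated times of 30 min and 1 h (on this read-out higher numbers stand for weaker inhibition and lower numbers for stronger inhibition), compound 1 gives > 200000 nM, a limit of the assay.
Compound 2 `CCCCCOS(=O)(=O)c1ccc(F)c2ncc(I)cc12`: in this assay compound 2 gives > 200000 nM, again a limit.
Compound 3 `CNS(=O)(=O)c1ccc(F)c2ncc(I)cc12`: in this assay compound 3 gives > 200000 nM, also a limit.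

Compound 3 stands at the limit, as do the two other values shown; nothing separates it from compound 1 or compound 2 by number. Among the measured steps, the change from compound 1 to compound 2 reads a step that the two limits leave unreadable from compound 1 to compound 2, that from compound 1 to compound 3 reads a step that the two limits leave unreadable from compound 1 to compound 3, and that from compound 2 to compound 3 reads a step that the two limits leave unreadable from compound 2 to compound 3; all three remain unreadable because of the limit of > 200000 nM in this assay, at which 3 of the 3 values shown sit. The new compound 4 `O=S(=O)(c1ccc(F)c2ncc(I)cc12)N1CCCC1` differs from compound 3 by pyrrolidin-1-yl in place of methylamino on a sulfonyl sulfur. The step from compound 2 to compound 3, which also exchanges the whole group on the sulfonyl sulfur, bears most closely on this change, yet neither it nor the others gives a size. Replacing the methylamino by pyrrolidin-1-yl on the sulfonyl sulfur is therefore expected to shift this assay by no readable amount; the expected step from compound 3 to compound 4 is a step that the limit leaves unreadable from compound 3 to compound 4. Compound 4 is estimated at 300000 nM in this assay, with a range from 100000 nM to 1000000 nM, and most likely it would again be reported only as a limit.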

Compound 4, half-maximal inhibitory concentration: > 200000 nM
Compound 4 gave a limit, no number (the forecaster's own chance of this, stated with the estimate: 85%); the middle value lies beyond the limit too.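

No step among compound 1, compound 2, compound 3 and compound 4 can be read in this assay, because all four stand at a limit and none gives a number: the limit of > 200000 nM in this assay, at which 4 of the 4 values shown sit.

The compounds shown leave open whether any group on the sulfonyl sulfur of the shared core gives a numerical value in this assay, and how far methoxy, pentyloxy, methylamino and pyrrolidin-1-yl differ.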